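The source may report more compounds than this note shows. Statements on the series, on what has been measured and on what is new or still open speak of the compounds shown alone.

Measured so far in a functional assay on PC-3 cells (Homo sapiens) for cytotoxicity, read by MTT assay, with a stated time of 48 h; a higher number here means a weaker inhibitor, a lower number a stronger inhibitor: compound 1 `CC1=NN(C(=O)CCl)C(c2cc(Br)ccc2O)C1`, 8890 nM; compound 2 `CC1=NN(C(=O)COc2ccc(Cl)cc2)C(c2cc(Br)ccc2O)C1`, 49000 nM.

Compound 2 holds the higher of the two numbers, standing apart from compound 1 by a 5.5-fold higher number from compound 1 to compound 2 (0.74 log units; beyond the scatter). Compound 3 `C=CCN(CC=C)CC(=O)N1N=C(C)CC1c1cc(Br)ccc1O` carries diallylamino in place of 4-chlorophenoxy on a saturated chain carbon bound to a carbonyl carbon. Within the data shown here, only that one step bears on this change, and it ran toward a higher number when 4-chlorophenoxy took the place of chloro. A second exchange at the same carbon has no measured parallel, so a small move back toward the lower side is expected, with wide uncertainty. The expected step is a 2.5-fold lower number from compound 2 to compound 3 (0.39 log units; beyond the scatter). Compound 3 is estimated at 20000 nM, in the range 5000 nM to 80000 nM.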

Compound 3, half-maximal inhibitory concentration: 3090 nM
Compound 3: middle estimate off by 6.5-fold (0.81 log units), on the high side; the measured number lies below the stated range.
By their numbers in this assay, from the lowest: compound 3; then compound 1; then compound 2.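

In this assay, among these compounds, the only earlier step at the saturated chain carbon bound to a carbonyl carbon ran upward, but diallylamino in place of 4-chlorophenoxy gives a 16-fold lower number from compound 2 to compound 3 (1.20 log units; beyond the scatter) and diallylamino in place of chloro gives a 2.9-fold lower number from compound 1 to compound 3 (0.46 log units; beyond the scatter) in the same series. The number at this carbon can therefore fall below that of the chloro compound as well as rise above it, and it moves with the group placed there. Nothing given here explains these differences.

As far as these compounds go, whether the nitrogen or the two allyl chains carry the change remains open. A dipropylamino group or a morpholine at this carbon would help separate the two.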